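Chloro for methyl on a quinolone amide series

The source may report more compounds than this note shows. Statements on the series, on what has been measured and on what is new or still open speak of the compounds shown alone.

Measured compounds in an assay on LX2 cells for inhibition of COL1A1 promoter (Homo sapiens), read by a luciferase reporter, with a stated time of 24 h, tested at 50 uM; on this read-out higher numbers stand for a stronger effect at the one concentration tested and lower numbers for a weaker effect:
compound 1, `Cc1cc(-n2cc(C(=O)Nc3cc(F)cc(F)c3)c(=O)c3ccc(N(C)C)nc32)ccc1OCCCCCCC[N+]1(C)CCN(C)CC1`, gives 32%
compound 2, `CN1CC[N+](C)(CCCCCCCOc2ccc(-n3cc(C(=O)Nc4cc(F)cc(F)c4)c(=O)c4ccc(N(C)C)nc43)cc2Cl)CC1`, gives 15.4%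
compound 3, `Cc1cc(OCCCCCCC[N+](C)(C)C2CCCCC2)ccc1-n1cc(C(=O)Nc2cc(F)cc(F)c2)c(=O)c2ccc(N(C)C)nc21`, is reported as "not active" (no number reported), with no number given

Compound 1 and compound 2 differ in one place, (chloro in place of methyl on an aromatic carbon). This change brought a number 16.6 percentage points lower from compound 1 to compound 2 (beyond the scatter). Compound 3 carries a different core; the difference between the two cores is not broken down here. Compound 4, `CN(C)c1ccc2c(=O)c(C(=O)Nc3cc(F)cc(F)c3)cn(-c3ccc(OCCCCCCC[N+](C)(C)C4CCCCC4)cc3Cl)c2n1`, is not yet measured and is related to compound 3 by chloro in place of methyl on an aromatic carbon, the same change as that from compound 1 to compound 2, at the same kind of place. Since compound 3 gave no measurable inhibition and the earlier change lowered the read-out, compound 4 is expected to show little or no inhibition in this assay, around 5%, between -10% and 20%.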

Compound 4, a percentage reported as inhibition, at one concentration (the size of the read-out at that concentration, not a potency): "not active" (no number reported)
Nothing numeric was reported for compound 4; no gap can be computed for the estimate.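

Compound 3 and compound 4 are both reported as not active in this assay, without a number, so the step from methyl to chloro between them cannot be read. Nothing shown here points to a cause. The compounds shown leave open whether this change lowers the read-out on the core of compound 3 as it did on that of compound 1.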